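The source may report more compounds than this note shows. Statements on the series, on what has been measured and on what is new or still open speak of the compounds shown alone.

Measured so far:
- compound 1, `COCCOc1cc2oc(=O)n(CCC(=O)O)c2cc1Cl`: 0.88
- compound 2, `C[C@@H](Oc1cc2onc(CCC(=O)O)c2cc1Cl)c1ccc(Cl)cn1`: 2.91

Two compounds have been run in a physicochemical assay for lipophilicity, read by HPLC, at pH 7.4; a higher number here means a more lipophilic compound, a lower number a more polar compound. Compound 1 gives 0.88 and stands lowest of the two numbers; compound 2 gives 2.91, a value well above compound 1 and beyond the usual scatter. The two compounds differ in several places at once, so the pair tells nothing about any single change.

The next compound, compound 3, `CCOc1cc2oc(=O)n(CCC(=O)O)c2cc1Cl`, is the close relative of compound 1 with one change: hydrogen in place of methoxy on a saturated chain carbon, two bonds along the chain from an oxygen on an aromatic ring. Going by the values given here, no measured pair of this kind exists here, so the expectation rests on the general behaviour of such a change rather than on a step within the set. Taking away an ether oxygen and its carbon from a side chain usually moves a compound toward the higher end of this assay, by an amount somewhat beyond the scatter, though not a large one. For compound 3 the estimate is 1.4, with a range from 0.95 to 1.9. This expected value means a step of a number 0.52 log units higher from compound 1 to compound 3 (beyond the scatter).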

Compound 3, distribution coefficient: 1.49
Compound 3: the middle estimate sits 0.09 log units below what was measured; the measured number falls inside the stated range.
By their numbers in this assay, from the lowest: compound 1; then compound 3; then compound 2.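

Notes on the side chain: on going from 2-methoxyethoxy to ethoxy, with the rest of the structure unchanged, this assay gives a number 0.61 log units higher from compound 1 to compound 3 (beyond the scatter), the first step in this series that can be tied to a single place. The reading at this position therefore responds to the outer end of the chain: hydrogen in place of methoxy, on a saturated chain carbon, two bonds along the chain from an oxygen on an aromatic ring, is enough to give a modest step beyond the scatter. Nothing at hand accounts for the size of this step.

A single step cannot separate the loss of the ether oxygen from the loss of the carbon that leaves with it, since methoxy goes as one unit and both heavy atoms change together. Still open, from the compounds shown here alone, is how the same position reads with a different group on that carbon, such as a propyl chain, which would keep the length without the oxygen, or an amine, and whether the step holds on any core other than that of compound 1.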